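The source may report more compounds than this note shows. Statements on the series, on what has been measured and on what is new or still open speak of the compounds shown alone.

Compound 1 `O=C(Nc1cccc(-c2ccco2)c1)C1CCCN(C(=O)c2cc(C(F)(F)F)cc(C(F)(F)F)c2)C1` is tested in an ADME assay on PC-3 cells (Homo sapiens) for cytotoxicity, read by WST assay, tested at 100 uM (on this read-out higher numbers stand for more inhibition at the one concentration tested (going by the name of the read-out) and lower numbers for less inhibition), where compound 1 gives 0%. Compound 2 `Cc1cccc(C(=O)N2CCCC(C(=O)Nc3ccc(Cl)cc3)C2)c1` gives 0% in this assay, so the two readings sit level at the digits shown, within the scatter of the method. Compound 3 `COC(=O)c1cccc(NC(=O)C2CCCN(C(=O)c3cc(C(F)(F)F)cc(C(F)(F)F)c3)C2)c1` has not yet been measured. It differs from compound 1 in one place: methoxycarbonyl in place of furan-2-yl on an aromatic carbon. Among the compounds with values here, no measured pair shows this kind of change, so the step of no change at the digits printed from compound 1 to compound 3 (within the scatter) is expected to stay within the scatter, with no clear direction. Compound 3 is therefore estimated to give 0% in this assay, with a range from -5% to 10%.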

Compound 3, a percentage reported as inhibition, at one concentration (the size of the read-out at that concentration, not a potency): 0%
Compound 3: middle estimate and measured number agree at the digits printed, and the stated range covers the measured number.
By their numbers in this assay, from the lowest: compounds 1, 2 and 3 (each within the scatter of the next).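

In this assay, within the data shown here, the step of no change at the digits printed from compound 1 to compound 3 (within the scatter) is the first measured change at this aromatic carbon. It replaces furan-2-yl, a five-membered aromatic ring, with methoxycarbonyl, which has no ring, so a ring at this place is not needed to keep the reading level. Nothing available explains this outcome.

On these data alone, whether an amine or a carboxylic acid on this carbon would also read level remains open. So does whether any change here can shift the reading at all, with every compound shown sitting level.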